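The compounds below may be only part of what the source reports. "The series", "measured", "known", "first", "only" and "open" are said of these compounds alone.

Working notes on the nitro-chromene pair and its ester extension.

Two analogues of the shared core have been run in an assay on 1321N1 cells for antagonist activity at P2Y purinoceptor 6 (Homo sapiens), read by FLIPR and calcium flux; a higher number here means a weaker inhibitor, a lower number a stronger inhibitor. Compound 1 `O=[N+]([O-])C1=Cc2ccc(Cl)cc2OC1C(F)(F)F` gives 7980 nM in this assay. Compound 2 `O=[N+]([O-])C1=Cc2cc(Cl)ccc2OC1C(F)(F)F`, carrying the chloro on the other available aromatic carbon, gives 1790 nM in this assay; compound 2 holds the lower of the two numbers, and its separation from compound 1 lies beyond the scatter of the method.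

Compound 3 `COC(=O)/C=C/c1ccc2c(c1)C=C([N+](=O)[O-])C(C(F)(F)F)O2` is the next member and has not yet been measured in this assay. It differs from compound 2 in one place: 2-(methoxycarbonyl)ethenyl in place of chloro on an aromatic carbon. Among the compounds with values here, no measured pair isolates this exchange, so there is no prior step to lean on. The expected step from compound 2 to compound 3 is a 1.5-fold lower number from compound 2 to compound 3 (0.17 log units; within the scatter) in this assay, and the estimate for compound 3 in this assay is 1200 nM, with a plausible range from 300 nM to 5000 nM.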

Compound 3, half-maximal inhibitory concentration: 2570 nM
Compound 3: middle estimate off by 2.1-fold (0.33 log units), on the low side, and the stated range covers the measured number.
By their numbers in this assay, from the lowest: compounds 2 and 3 (each within the scatter of the next); then compound 1.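

In this assay, the exchange of chloro for 2-(methoxycarbonyl)ethenyl on this aromatic carbon gives a 1.4-fold higher number from compound 2 to compound 3 (0.16 log units; within the scatter), the first indication of what this position accepts. A group of 6 heavy atoms with 2 hydrogen-bond acceptors replaces a single chlorine with no change beyond the scatter, so in this one pair chloro is not required at this carbon for a number of this size. Nothing available here explains why the exchange leaves the number within the scatter.

From the compounds shown here alone, whether this position accepts other groups in the same way remains open, for example a carboxylic acid, an amine or a longer chain. Also open, going by these compounds, is whether 2-(methoxycarbonyl)ethenyl would give a similar step in place of the chloro of compound 1, on the other aromatic carbon.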